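A few compounds are considered here, and "the series" means these few. Any claim that something is new, unique, unknown or untested is made for them only; others in the source may bear on it.

Compound 1 `Cc1cc(NC(=O)Cn2nnc(-c3ccccc3)n2)n(C2CCCCC2)n1` gives 87 mL/min/kg in an ADME assay on cells (Hepatocyte, Mus musculus) for pharmacokinetics; a higher number here means faster removal of the compound, a lower number slower removal.
Compound 2 `Cc1cc(NC(=S)Cn2nnc(-c3ccccc3)n2)n(C2CCCCC2)n1` gives only a limit of the assay, > 88.7 mL/min/kg, in this assay.

Within the data shown here, compound 1 therefore holds the only outright number here, and it sits at the fast end of removal. Compound 3 `Cc1cc(NC(=O)Cn2nnc(-c3ccccc3)n2)n(C2CCC(F)(F)CC2)n1` has not yet been measured; it differs from compound 1 by 4,4-difluorocyclohexyl in place of cyclohexyl on an aromatic nitrogen. Among the measured compounds shown here, no measured pair shows what such a change does, so the step from compound 1 to compound 3 is expected to be a modest fall toward slower removal, a 1.5-fold lower number from compound 1 to compound 3 (0.16 log units; within the scatter), possibly no larger than the usual scatter. Compound 3 is estimated at 60 mL/min/kg, with a range from 30 mL/min/kg to 89 mL/min/kg.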

Compound 3, clearance: 80 mL/min/kg
Compound 3: middle estimate off by 1.3-fold (0.12 log units), on the low side; measured number inside the range.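

Within this assay the swap of cyclohexyl for 4,4-difluorocyclohexyl on the aromatic nitrogen gives a 1.1-fold lower number from compound 1 to compound 3 (0.04 log units; within the scatter) and so provides the first measured step at this position. Removal of compound 3 cannot be told apart from that of compound 1, so this change leaves both at the fast end. Nothing measured here accounts for this result. Still open, as far as these compounds go, is whether another group on this nitrogen, such as a morpholine ring or a short chain ending in an amine, would give a clearly lower number than compound 1.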